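This account rests on a few compounds, and the source may have more. Where it says the series, first, only, none or still open, it means among the compounds named here.

In a functional assay on A549 cells (Homo sapiens) for inhibition, read by MTT assay, with a stated time of 24 h (on this read-out higher numbers stand for weaker inhibition and lower numbers for stronger inhibition), compound 2 `CC1(C)[C@H]2CC[C@]1(C)N(Cc1cn(-c3ccccc3O)nn1)C(=O)C2` gives 230 nM and compound 1 `CC1(C)[C@H]2CC[C@]1(C)N(Cc1cn(-c3ccc(C#N)cc3)nn1)C(=O)C2` gives 140 nM, two values within the scatter of each other. Compound 3 `Cc1cccc(-n2cc(CN3C(=O)C[C@@H]4CC[C@@]3(C)C4(C)C)nn2)c1` differs from compound 2 as follows: 3-methylphenyl in place of 2-hydroxyphenyl on an aromatic nitrogen. Within the data shown here, the only measured step at this aromatic nitrogen is a 1.6-fold higher number from compound 1 to compound 2 (0.22 log units; within the scatter), which stays within the scatter and involves a different group, 4-cyanophenyl. No step beyond the scatter is therefore expected in this assay. The expected step is a 1.2-fold lower number from compound 2 to compound 3 (0.06 log units; within the scatter). Compound 3 is estimated at 200 nM, with an expected range of 80 nM to 500 nM.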

Compound 3, half-maximal inhibitory concentration: 50 nM
For compound 3 the middle estimate is 4.0-fold (0.60 log units) above the measured one; measured number below the stated range.
By their numbers in this assay, from the lowest: compound 3; then compounds 1 and 2 (each within the scatter of the next).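

In this assay, the group on this aromatic nitrogen can move the number beyond the scatter: 3-methylphenyl gives a 4.6-fold lower number from compound 2 to compound 3 (0.66 log units; beyond the scatter) and, against the other earlier aryl group, a 2.8-fold lower number from compound 1 to compound 3 (0.45 log units; beyond the scatter). Neither a hydrogen-bond donor nor a hydrogen-bond acceptor on the aryl group is needed for the lowest number in this set, since 3-methylphenyl has 0 of each.

From the compounds shown here alone, how a phenyl ring bearing an amine or a carboxylic acid would read here remains open. No available evidence accounts for these steps.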